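Methyl on the ring nitrogen across two related cores

The source may hold more compounds than are shown below. What is called first, only, known or untested is meant among the compounds shown, and "the series" means these compounds.

Measured so far:
compound 1, `CN(c1ccc(Oc2ncnc3ccsc23)cc1)c1nccc(N2CCc3ccccc3C2)n1`: 30.2%
compound 2, `c1ccc2c(c1)CCN(c1ccnc(Nc3ccc(Oc4ncnc5ccsc45)cc3)n1)C2`: 15.4%
compound 3, `c1ccc2c(c1)CCN(c1ccnc(Nc3ccc(Oc4ncnc5sccc45)cc3)n1)C2`: 26.8%

All three were tested in a functional assay on MDA-MB-231 cells (Homo sapiens) for inhibition, read by MTT assay, with a stated time of 72 h, tested at 20 uM; a higher number here means more inhibition at the concentration tested (going by the name of the read-out), a lower number less inhibition. Compound 2 and compound 3 share every atom but are joined differently: the difference is a group of 9 heavy atoms (6 carbon, 2 nitrogen, 1 sulfur; one five-membered aromatic ring with 1 hetero atom, one six-membered aromatic ring with 2 hetero atoms) in place of a group of 9 heavy atoms (6 carbon, 2 nitrogen, 1 sulfur; one five-membered aromatic ring with 1 hetero atom, one six-membered aromatic ring with 2 hetero atoms), on an oxygen on an aromatic ring, and the step it made is a number 11.4 percentage points higher from compound 2 to compound 3 (beyond the scatter). Compound 1 differs from compound 2 by methyl in place of hydrogen on a nitrogen on an aromatic ring, a change that gave a number 14.8 percentage points higher from compound 2 to compound 1 (beyond the scatter). Compound 3 and compound 1 are within the scatter of each other, while compound 2 sits beyond the scatter below both.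

Compound 4, `CN(c1ccc(Oc2ncnc3sccc23)cc1)c1nccc(N2CCc3ccccc3C2)n1`, has not yet been measured. It differs from compound 3 by methyl in place of hydrogen on a nitrogen on an aromatic ring. The place of this change is the same, word for word, as the place of the change from compound 2 to compound 1, so it is the same change, made here on the core of compound 3 instead of the core of compound 2. It occurs twice among the compounds shown.

For compound 4 the expected step is a number 13.2 percentage points higher from compound 3 to compound 4 (beyond the scatter), set beside the earlier a number 14.8 percentage points higher from compound 2 to compound 1 (beyond the scatter), because compound 1 against compound 2 showed a number 14.8 percentage points higher from compound 2 to compound 1 (beyond the scatter) and the change is the same one. Within the data shown here, only one earlier instance is known, so the size is taken with caution. Compound 4 is thus expected to give 40% in this assay, with a likely range from 28% to 52%.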

Compound 4, a percentage reported as inhibition, at one concentration (the size of the read-out at that concentration, not a potency): 24.3%
Compound 4: middle estimate off by 15.7 percentage points, on the high side; measured number outside the range, below it.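

In this assay, methyl in place of hydrogen on a nitrogen on an aromatic ring gave a number 2.5 percentage points lower from compound 3 to compound 4 (within the scatter), so the rise seen on the core of compound 2 did not carry over to the core of compound 3: the same change on two cores in this assay, a number 14.8 percentage points higher (beyond the scatter) from compound 2 to compound 1 and a number 2.5 percentage points lower (within the scatter) from compound 3 to compound 4, 17.3 percentage points apart, beyond the scatter of two such steps. Read the other way round, exchanging the group on the oxygen on an aromatic ring also gave a different outcome once the methyl was present, with a number 5.9 percentage points lower from compound 1 to compound 4 (within the scatter): the same change on two cores in this assay, a number 11.4 percentage points higher (beyond the scatter) from compound 2 to compound 3 and a number 5.9 percentage points lower (within the scatter) from compound 1 to compound 4, 17.3 percentage points apart, beyond the scatter of two such steps. Together these show that, for this pair of cores, the two changes do not simply add and the step from one cannot be transferred unchanged to the other, but they do not show why, and with only four compounds read at a single concentration they give no rule for any further core.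

The compounds shown leave open whether a longer chain such as ethyl, or an acyl group such as acetyl, on that same nitrogen would depend on the core in the same way. They also leave open whether an amine or a carboxylic acid carried elsewhere on these molecules would follow the pattern of the methyl step on either core.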